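A few compounds are considered here, and "the series" means these few. Any claim that something is new, unique, unknown or untested is made for them only; others in the source may bear on it.

Measured compounds in a functional assay on A2780 cells (Homo sapiens) for cytotoxicity, read by MTT assay, with a stated time of 48 h; on this read-out higher numbers stand for weaker inhibition and lower numbers for stronger inhibition:
compound 1 `CCn1cc(-c2nc3ccccc3s2)c(=O)c2cc(F)c(N3CCN(C)CC3)cc21` gives 114000 nM
compound 2 `CCn1cc(-c2nc3ccc([N+](=O)[O-])cc3s2)c(=O)c2cc(F)c(N3CCNCC3)cc21` gives 700 nM

For the measured compounds named here, compound 2 stands at the lower of the two numbers in this assay; compound 1 sits far higher, beyond the scatter, but the two differ at more than one place, so no single-change step can be drawn from them. Compound 3 `CCn1cc(-c2nc3ccc([N+](=O)[O-])cc3s2)c(=O)c2cc(F)c(N3CCN(C)CC3)cc21` carries methyl in place of hydrogen on an amine nitrogen in a ring relative to compound 2. Going by the values given here, with no comparable step available, a modest shift toward weaker inhibition is expected, so the step from compound 2 to compound 3 is estimated as a 2.9-fold higher number from compound 2 to compound 3 (0.46 log units; beyond the scatter). Compound 3 is accordingly expected to give about 2000 nM, with a range from 500 nM to 12000 nM.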

Compound 3, half-maximal inhibitory concentration: 4300 nM
The estimate for compound 3 lay 2.2-fold (0.33 log units) below the measured number; the measured number falls inside the stated range.
By their numbers in this assay, from the lowest: compound 2; then compound 3; then compound 1.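

In this assay, for the compounds shown here, going from piperazin-1-yl to 4-methylpiperazin-1-yl weakens inhibition, with a 6.1-fold higher number from compound 2 to compound 3 (0.79 log units; beyond the scatter) as the first single-place reading at this ring nitrogen. With the 4-methylpiperazin-1-yl group held constant, nitro in place of hydrogen on the aromatic carbon gives a 27-fold lower number from compound 1 to compound 3 (1.42 log units; beyond the scatter), so this large step strengthens inhibition.

Still open, from the compounds shown here alone, is whether an ethyl group or a longer chain on the ring nitrogen extends the methyl trend, and whether an amine or a nitrile can stand in for nitro. Nothing measured here accounts for either step.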